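Adding a methoxy group on a benzylamine-bearing isoxazole core

A few compounds are considered here, and "the series" means these few. Any claim that something is new, unique, unknown or untested is made for them only; others in the source may bear on it.

Measured compounds:
compound 1 `COc1ccc(CNC(=O)c2c([N+](=O)[O-])noc2-c2ccc(Cl)cc2)cc1` 89500 nM
compound 2 `COc1ccc(CNC(=O)c2c([N+](=O)[O-])noc2-c2ccc(Cl)cc2)cc1OC` 106000 nM
compound 3 `COC(=O)c1c(NCc2ccc(OC)cc2)noc1-c1ccc(Cl)cc1Cl` 34700 nM

In an ADME assay on J774.A1 cells (Mus musculus) for cytotoxicity, read by MTT assay, with a stated time of 48 h (a lower number here means that less compound is tolerated, a higher number that more compound is tolerated), compound 1 gives 89500 nM. The change to compound 2 is methoxy in place of hydrogen on an aromatic carbon, and it gave a 1.2-fold higher number from compound 1 to compound 2 (0.07 log units; within the scatter). Compound 3 stands on a different core; the difference between the two cores is not broken down here. In this assay compound 3 gives 34700 nM, the lowest of the three numbers, with the gaps to compound 1 and to compound 2 beyond the scatter.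

Compound 4 `COC(=O)c1c(NCc2ccc(OC)c(OC)c2)noc1-c1ccc(Cl)cc1Cl` is not yet measured. It differs from compound 3 by methoxy in place of hydrogen on an aromatic carbon, the same change as from compound 1 to compound 2. Because that earlier step was a 1.2-fold higher number from compound 1 to compound 2 (0.07 log units; within the scatter), a step of similar size is expected, namely a 1.2-fold higher number from compound 3 to compound 4 (0.06 log units; within the scatter). Compound 4 is therefore estimated at 40000 nM, between 20000 nM and 80000 nM.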

Compound 4, half-maximal cytotoxic concentration: 7580 nM
For compound 4 the middle estimate is 5.3-fold (0.72 log units) above the measured one; measured number outside the range, below it.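

On the second core, methoxy in place of hydrogen on an aromatic carbon gave a 4.6-fold lower number from compound 3 to compound 4 (0.66 log units; beyond the scatter) in this assay, so less of the compound is tolerated there. The step seen on the first core therefore did not carry over, and the two results differ: the same change on two cores in this assay, a 1.2-fold higher number (0.07 log units; within the scatter) from compound 1 to compound 2 and a 4.6-fold lower number (0.66 log units; beyond the scatter) from compound 3 to compound 4, 5.4-fold (0.73 log units) apart, beyond the scatter of two such steps This rests on just two pairs and does not show which feature of the cores separates them, nor does it give a rule for other cores in the series.

As far as these compounds go, whether a hydroxy or an ethoxy group on the same aromatic carbon would follow the methoxy step on either core remains open. So does how a carboxylic acid on the second core would read in this assay.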